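A few compounds are considered here, and "the series" means these few. Any claim that something is new, unique, unknown or untested is made for them only; others in the source may bear on it.

Series values in a functional assay on UACC-62 cells (Homo sapiens) for inhibition, read by sulforhodamine B assay, with a stated time of 48 h; a higher number here means a weaker inhibitor of growth, a lower number a stronger inhibitor of growth:
- Compound 1 `COc1ccc(/C=C/C2(C)C=CC(=O)O2)c(OC)c1`: 80100 nM
- Compound 2 `COc1ccc(/C=C/C2(C)C=CC(=O)O2)cc1OC`: 84100 nM

Going by the values given here, compound 2 stands within the scatter of compound 1, the only other measured compound. Compound 3 `COc1ccc(/C=C/C2(C)C=CC(=O)O2)cc1` departs from compound 2 by hydrogen in place of methoxy on an aromatic carbon, with hydrogen in place of methoxy on an aromatic carbon. Among the compounds with values here, no measured pair shows this change directly, so the expectation rests on two close values: in this assay, compound 1 gives 80100 nM and compound 2 gives 84100 nM. The expected change is small, with no direction beyond the scatter: a 1.1-fold higher number from compound 2 to compound 3 (0.03 log units; within the scatter). For compound 3, the estimated value is 90000 nM, with an expected range of 45000 nM to 180000 nM.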

Compound 3, concentration for total growth inhibition: 147000 nM
Beside the measured number, compound 3's estimate is 1.6-fold (0.21 log units) below it; low and high end bracket the measured number.
By their numbers in this assay, from the lowest: compounds 1, 2 and 3 (each within the scatter of the next).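

In this assay, hydrogen in place of methoxy on an aromatic carbon, ortho to a methoxy group and meta to a group of 9 heavy atoms, gives a 1.7-fold higher number from compound 2 to compound 3 (0.24 log units; within the scatter) at this position, and the same kind of exchange gives a 1.8-fold higher number from compound 1 to compound 3 (0.26 log units; within the scatter) as well. Neither step lies beyond the scatter, so these compounds do not show that this methoxy is needed.

From the compounds shown here alone, whether an amine or a carboxylic acid on this aromatic carbon would give a step beyond the scatter remains open. No available measurement explains these steps.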